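A few compounds are considered here, and "the series" means these few. Any claim that something is new, unique, unknown or untested is made for them only; others in the source may bear on it.

Measured so far in a functional assay on CHO cells for positive allosteric modulation of muscarinic acetylcholine receptor M5 (Homo sapiens), read by calcium flux; on this read-out lower numbers stand for smaller maximal responses and higher numbers for larger maximal responses:
compound 1, `CCN(Cc1ccccc1)C(=O)C1CCN(S(=O)(=O)c2ccc3cccnc3c2)CC1`: 66%
compound 2, `CCN(C(=O)C1CCN(S(=O)(=O)c2ccc(OC)cc2)CC1)[C@H](C)c1ccccc1`: 90%
compound 3, `CCN(Cc1ccccc1F)C(=O)C1CCN(S(=O)(=O)c2ccc3cn[nH]c3c2)CC1`: 84%

Compound 3 holds the second highest of the three numbers in this assay. Its nearest neighbour is compound 2, whose number is higher but within the scatter, so no order between compound 2 and compound 3 can be read. Compound 1 lies further away, its lower number beyond the scatter.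

Compound 4, `CCN(Cc1ccccc1Cl)C(=O)C1CCN(S(=O)(=O)c2ccc3cn[nH]c3c2)CC1`, differs from compound 3 in a single place: chloro in place of fluoro on an aromatic carbon. Among the compounds with values here, no pair among the measured compounds differs in one place, so no measured step guides the expectation; the change is small, fluoro leaving and chloro entering on the same aromatic carbon.

For compound 4 the expected step is a number 2 percentage points lower from compound 3 to compound 4 (within the scatter), no larger than the scatter. Compound 4 is thus estimated at 82%, within 68% to 96%.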

Compound 4, largest response reached (reported as percent of maximum), in percent of the reference or control that the assay uses: 93%
For compound 4 the middle estimate is 11 percentage points below the measured one, and the stated range covers the measured number.
By their numbers in this assay, from the lowest: compound 1; then compounds 3, 2 and 4 (each within the scatter of the next).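

In this assay, within the data shown here, the one pair that differs in a single place gives a number 9 percentage points higher from compound 3 to compound 4 (within the scatter), so 2-fluorobenzyl and 2-chlorobenzyl cannot be told apart on this read-out. At this aromatic carbon, ortho to a large group, the swap of one halogen for the other thus leaves the response within the scatter. Nothing at hand bears on the reason for this step.

Still open, going by these compounds, is whether a nitrile or an amine on this same carbon would keep the response. Also open, on these data alone, is whether the swap reads the same with another sulfonyl aryl group on the shared core.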